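The compounds below may be only part of what the source reports. "The series", "measured", "known", "first", "only" and "open" are said of these compounds alone.

Of the compounds shown here, three sharing one core have been measured so far. In a functional assay on SGC-7901 cells (Homo sapiens) for antiproliferative activity, read by MTT assay, with a stated time of 48 h (on this read-out higher numbers stand for weaker inhibition and lower numbers for stronger inhibition), compound 2 `COc1ccc(-c2nnc(SCc3ccc(Cl)nc3)o2)cc1` gives 3.5 ug/mL and compound 1 `Cc1ccc(-c2nnc(SCc3ccc(Cl)nc3)o2)cc1` gives 3.62 ug/mL. These two values lie within the scatter of each other, at the low end of the three numbers. Compound 3 `CCOc1ccccc1-c1nnc(SCc2ccc(Cl)nc2)o1` stands apart from both at 10.3 ug/mL.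

Compound 4 `CCOc1ccc(-c2nnc(SCc3ccc(Cl)nc3)o2)cc1` differs from compound 2 by methyl in place of hydrogen on a saturated chain carbon bound to an oxygen on an aromatic ring, which turns methoxy into ethoxy. Within the data shown here, no measured step shows this exact change. The closest evidence is a 1.0-fold lower number from compound 1 to compound 2 (0.01 log units; within the scatter), methoxy in place of methyl on an aromatic carbon, and that step stayed within the scatter. Compound 3 also carries ethoxy, but not where compound 4 carries it, so it offers only a caution, with compound 3 at 10.3 ug/mL favouring a wide upper margin.

An expected 1.1-fold higher number from compound 2 to compound 4 (0.06 log units; within the scatter) is therefore small, with no shift beyond the scatter anticipated. For compound 4 the estimate is 4 ug/mL, with an expected range of 2 ug/mL to 8.5 ug/mL.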

Compound 4, half-maximal inhibitory concentration: 4.97 ug/mL
For compound 4 the middle estimate is 1.2-fold (0.09 log units) below the measured one, and the stated range covers the measured number.
By their numbers in this assay, from the lowest: compounds 2, 1 and 4 (each within the scatter of the next); then compound 3.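

In this assay, extending methoxy to ethoxy gives a 1.4-fold higher number from compound 2 to compound 4 (0.15 log units; within the scatter), and ethoxy in place of methyl on the aromatic carbon gives a 1.4-fold higher number from compound 1 to compound 4 (0.14 log units; within the scatter), so methyl, methoxy and ethoxy at this position cannot be told apart on these numbers. Ethoxy as such therefore does not go with a high number, since compound 4 does not share the value of compound 3, 10.3 ug/mL, which carries ethoxy elsewhere. No measurement offered here accounts for these small steps.

The compounds shown leave open how far this flat reading extends along the chain, as a longer chain such as butoxy could either continue it or break it. They also leave open whether a group of a different kind at this position, such as an amine or a carboxylic acid, would stay within the scatter of these values.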